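The source may report more compounds than this note shows. Statements on the series, on what has been measured and on what is new or still open speak of the compounds shown alone.

Working notes on the series. Three compounds have numbers in an assay on HEK293 cells for activation of Kir3.1/Kir3.2 (Homo sapiens), read by thallium flux; a lower number here means a smaller maximal response, a higher number a larger maximal response. Compound 1 `Cc1cc(NC(=O)Cn2nnc(-c3ccccc3)n2)n(C2CCCC2)n1` gives 105%. Compound 2 `O=C(Cn1nnc(-c2ccccc2)n1)Nc1cc(C2CC2)nn1C1CCCCC1` gives 45%. Compound 3 `Cc1cc(NC(=O)Cn2nnc(-c3ccc(Cl)c(Cl)c3)n2)n(C2CCCCC2)n1` gives 84%, which places it second highest of the three: compound 1 stands above it by a gap beyond the scatter, and compound 2 stands below it by a larger gap, also beyond the scatter. No pair among these three differs in only one place, so no single change can be tied to any of these gaps.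

Compound 4 `COc1ccc(-c2nnn(CC(=O)Nc3cc(C)nn3C3CCCCC3)n2)cc1` differs from compound 3 in one place: 4-methoxyphenyl in place of 3,4-dichlorophenyl on an aromatic carbon. Nothing measured here speaks to this particular exchange. For compound 4 the step of a number 6 percentage points lower from compound 3 to compound 4 (within the scatter) is expected to be small, with a slight lean downward, and possibly none beyond the scatter. Compound 4 is therefore estimated at 78% in this assay, within a range from 50% to 105%, the width reflecting the absence of any paired step in the data.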

Compound 4, largest response reached (Emax), in percent of the reference or control that the assay uses: 90%
Compound 4: the middle estimate sits 12 percentage points below what was measured, within the range that was stated.
By their numbers in this assay, from the lowest: compound 2; then compounds 3 and 4 (each within the scatter of the next); then compound 1.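

Among these compounds, the exchange of 3,4-dichlorophenyl for 4-methoxyphenyl on the aromatic carbon of the five-membered ring gives, in this assay, a number 6 percentage points higher from compound 3 to compound 4 (within the scatter) and is the first paired step. With these two groups at this position, compound 3 and compound 4 cannot be told apart by maximal response, even though 4-methoxyphenyl carries a hydrogen-bond acceptor and 3,4-dichlorophenyl carries none. Nothing available here offers an explanation for this result.

Among the compounds shown here, the pair covers only two substituted phenyl groups, so it remains open whether a carboxylic acid or an amine on the phenyl ring would also leave the maximal response within the scatter. It also leaves open how each chlorine of 3,4-dichlorophenyl and the methoxy group contribute on their own.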